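A New Group on the Carbonyl Carbon

The source may report more compounds than this note shows. Statements on the series, on what has been measured and on what is new or still open speak of the compounds shown alone.

Compound 1 (`COc1cc(-c2nn(-c3cccc(NC(=O)c4cccc(C(F)(F)F)c4)c3)cc2-c2ccncc2)ccc1Cl`) is the starting point, tested in a functional assay on CAKI-1 cells (Homo sapiens) for inhibition, read by sulforhodamine B assay, with a stated time of 48 h; a higher number here means a weaker inhibitor of growth, a lower number a stronger inhibitor of growth. Here compound 1 gives > 50000 nM, which is a limit of the assay and not a number. Among the compounds with values here, the only measured number comes from compound 2 (`O=C(Nc1cccc(-n2cc(-c3ccncc3)c(-c3ccc(Cl)c(O)c3)n2)c1)Nc1cc(C(F)(F)F)cc(C(F)(F)F)c1`), which gives 4420 nM in this assay.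

Compound 3 (`COc1cc(-c2nn(-c3cccc(NC(=O)Nc4ccc(Cl)c(C(F)(F)F)c4)c3)cc2-c2ccncc2)ccc1Cl`) has not yet been measured. It departs from compound 1 in one place, with (4-chloro-3-(trifluoromethyl)phenyl)amino in place of 3-(trifluoromethyl)phenyl on a carbonyl carbon.

Within the data shown here, no measured pair of compounds isolates this change, so any forecast is tentative. Compound 2 also carries a substituted phenylamino group on its carbonyl carbon, and its 4420 nM is the best available guide, although it differs from compound 3 elsewhere too. On that basis, stronger inhibition of growth is expected, with a clear step rather than one lost in the scatter. The estimated move is an at least 6.2-fold lower number from compound 1 to compound 3 (0.79 log units; beyond the scatter). For compound 3 the expected value is 8000 nM, with an estimated range from 2500 nM to 40000 nM.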

Compound 3, concentration for total growth inhibition: 4720 nM
The estimate for compound 3 lay 1.7-fold (0.23 log units) above the measured number, within the range that was stated.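

In this assay, putting (4-chloro-3-(trifluoromethyl)phenyl)amino in place of 3-(trifluoromethyl)phenyl on a carbonyl carbon gives an at least 10-fold lower number from compound 1 to compound 3 (1.02 log units; beyond the scatter), the first sign that this one position can move growth inhibition by a large step. For compound 1, the value of > 50000 nM is a limit of the assay and not a number. The step can therefore be read only as a minimum, because its starting point lies at that limit: the limit of > 50000 nM in this assay, at which 1 of the 3 values shown sits.

The change brings in two new features at once, a chlorine on the ring and a nitrogen carrying a hydrogen-bond donor, so the compounds shown cannot say whether one of them, or only the two together, accounts for the step. A 3-(trifluoromethyl)phenylamino group or a 4-chloro-3-(trifluoromethyl)phenyl group on the same carbonyl carbon would separate the two, while a small amine such as methylamino would show whether the aromatic ring at this position is needed at all.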